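Five-membered heteroaryl swaps on a salicylic acid core

This account rests on a few compounds, and the source may have more. Where it says the series, first, only, none or still open, it means among the compounds named here.

Measured compounds:
- compound 1, `O=C(O)c1cc(-c2c[nH]cn2)ccc1O`: 100 mg/kg
- compound 2, `O=C(O)c1cc(C2N=NN=N2)ccc1O`: 110 mg/kg
- compound 3, `O=C(O)c1cc(-c2ccno2)ccc1O`: 110 mg/kg

All three share a salicylic acid core and differ only in the five-membered ring attached to it, read in a functional assay on the whole organism for inhibition, with Rattus norvegicus as the target, read by paw edema; a higher number here means that more compound is needed for the effect, a lower number that less compound is needed. Compound 3 stands level with compound 2 at the digits printed, the two together the highest of the three numbers, with compound 1 nearest below; every gap is within the scatter, so no order among the three can be claimed.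

Compound 4, `O=C(O)c1cc(-n2ccnn2)ccc1O`, is the next member. Its change from compound 3 is 1H-1,2,3-triazol-1-yl in place of 1,2-oxazol-5-yl on an aromatic carbon. The measured steps of the same kind bear on it: the ring swap from compound 1 to compound 3 gave a 1.1-fold higher number from compound 1 to compound 3 (0.04 log units; within the scatter), the swap from compound 2 to compound 3 gave no change at the digits printed from compound 2 to compound 3 (within the scatter), and the swap from compound 1 to compound 2 gave a 1.1-fold higher number from compound 1 to compound 2 (0.04 log units; within the scatter). Three different five-membered rings at this position, aromatic or not, with two to four heteroatoms, left this assay flat. On that basis no step beyond the scatter is expected for compound 4 in this assay, in either direction, that is no change at the digits printed from compound 3 to compound 4 (within the scatter).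

Compound 4 is accordingly estimated at 110 mg/kg, with an expected range from 65 mg/kg to 180 mg/kg.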

Compound 4, dose for half-maximal effect: 150 mg/kg
Compound 4: middle estimate off by 1.4-fold (0.13 log units), on the low side, within the range that was stated.
By their numbers in this assay, from the lowest: compounds 1, 2, 3 and 4 (each within the scatter of the next).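

In this assay, the place para to the hydroxy group and meta to the carboxy group also accommodates 1H-1,2,3-triazol-1-yl, the only ring of the four joined to the core through a ring nitrogen, with a 1.4-fold higher number from compound 3 to compound 4 (0.13 log units; within the scatter), a 1.4-fold higher number from compound 2 to compound 4 (0.13 log units; within the scatter) and a 1.5-fold higher number from compound 1 to compound 4 (0.18 log units; within the scatter). Compound 4 therefore extends the flat reading to a ring with a different point of attachment, and the swap from 1,2-oxazol-5-yl, with its 2 hydrogen-bond acceptors, to a ring with 3 gives no step beyond the scatter. No supporting data bear on this result, so the reading stays purely descriptive.

All four groups at this place are five-membered rings, so the compounds shown leave open how this assay responds to a six-membered ring such as phenyl or pyridyl, or to an open group such as an amine or a longer alkyl chain. They also leave open whether the same insensitivity would hold if the carboxylic acid of the shared core gave way to an amide or an ester.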